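This account rests on a few compounds, and the source may have more. Where it says the series, first, only, none or still open, it means among the compounds named here.

Measured so far in a functional assay on HOP-62 cells (Homo sapiens) for inhibition, read by sulforhodamine B assay; on this read-out lower numbers stand for stronger inhibition of growth and higher numbers for weaker inhibition of growth:

Compound 1 `c1ccc(-c2ccc(-c3ccc(-c4nc5ccccc5[nH]4)cc3)cc2)cc1` gives 100000 nM.
Compound 2 `FC(F)(F)c1ccc(-c2ccc(-c3ccc(-c4nc5ccccc5[nH]4)cc3)cc2)cc1` gives 100000 nM.

For the measured compounds named here, on these numbers compound 2 stands level with compound 1, the only other compound measured, and the two cannot be told apart in this assay.

The next compound, compound 3 `FC(F)(F)Oc1ccc(-c2ccc(-c3ccc(-c4nc5ccccc5[nH]4)cc3)cc2)cc1`, carries trifluoromethoxy in place of trifluoromethyl on an aromatic carbon, para to a large group. The difference is trifluoromethoxy in place of trifluoromethyl on an aromatic carbon.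

Going by the values given here, only one measured step bears on this change, and it is an indirect guide. Adding trifluoromethyl in place of hydrogen on an aromatic carbon gave no change at the digits printed from compound 1 to compound 2 (within the scatter). Among the compounds with values here, no measured compound yet carries trifluoromethoxy, so the data hold no direct test of this group. With that single step showing no movement, no step beyond the scatter is expected here, although some gain in growth inhibition cannot be excluded. The expected step is no change at the digits printed from compound 2 to compound 3 (within the scatter). The estimate for compound 3 is 100000 nM, with an estimated range from 40000 nM to 100000 nM.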

Compound 3, concentration for 50% growth inhibition: 100000 nM
The estimate for compound 3 equals the measured number at the digits printed; the range from low to high includes it.
By their numbers in this assay, from the lowest: compounds 1, 2 and 3 (each within the scatter of the next).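

In this assay, the place on an aromatic carbon para to a large group now has a second fluorinated group on record: trifluoromethoxy in place of trifluoromethyl, which brings in an oxygen and a hydrogen-bond acceptor, gave no change at the digits printed from compound 2 to compound 3 (within the scatter) in this comparison. Set against hydrogen at the same place, trifluoromethoxy gave no change at the digits printed from compound 1 to compound 3 (within the scatter) as well, so the earlier flat result was not confined to trifluoromethyl, and neither fluorinated group can be told apart from hydrogen here. Nothing available accounts for this flat result.

As far as these compounds go, it remains open whether any group at this place can shift growth inhibition in this read-out, for instance an amine or a carboxylic acid in place of the trifluoromethoxy. From the compounds shown here alone, it is also open whether a change elsewhere on the shared core, such as a methyl or a chlorine on the ring system bearing the nitrogens, would separate these compounds, or whether they would stay level in a different cell line.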